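The compounds below may be only part of what the source reports. "The series", "measured", "known", "first", "only" and "open" are said of these compounds alone.

Measured compounds in a functional assay on MIA PaCa-2 cells (Homo sapiens) for inhibition, read by MTT assay, with a stated time of 3 days; a lower number here means a stronger inhibitor, a higher number a weaker inhibitor:
Compound 1, `O=C([C@@H]1CCCN(S(=O)(=O)c2ccc(S(=O)(=O)N3CC[C@@H](O)C3)cc2)C1)N1CCC(F)(F)CC1`, gives > 3000 nM; this is a limit of the assay, not a number.
Compound 2, `CCN(CC)S(=O)(=O)c1ccc(S(=O)(=O)N2CCC[C@@H](C(=O)N3CCC(C(F)(F)F)CC3)C2)cc1`, gives > 10000 nM; this too is a limit of the assay rather than a number.

Compound 2 stands at the limit of > 10000 nM in this assay, at which 1 of the 2 values shown sits, and compound 1 stands at the limit of > 3000 nM in this assay, at which 1 of the 2 values shown sits. Since neither value is a number, the gap between the two measured compounds cannot be sized, and nothing can be said of their order; both simply sit at the weak end of what this assay reports.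

Compound 3, `CCN(CC)S(=O)(=O)c1ccc(S(=O)(=O)N2CCC[C@@H](C(=O)N3CCC(COC)CC3)C2)cc1`, has not yet been measured. It differs from compound 2 in one place: methoxymethyl in place of trifluoromethyl on a saturated ring carbon. The exchange swaps one uncharged group without a ring for another on the same saturated ring carbon, and the compound carrying the trifluoromethyl returned only a limit.

Among the measured compounds shown here, with no numbered value for either measured compound there is no step to lean on. Compound 3 is therefore expected to remain weak, with a step that the limit leaves unreadable from compound 2 to compound 3 expected to lie within the scatter, and most likely to return again only a limit in this assay. The estimate for compound 3 in this assay is 15000 nM, expected to fall between 5000 nM and 50000 nM.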

Compound 3, half-maximal inhibitory concentration: > 10000 nM
Compound 3: only a limit was reported; the forecaster's own chance of this, stated with the estimate: 80%; the middle value does not contradict the limit.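

In this assay compound 3 gives > 10000 nM, which is a limit of the assay and not a number. Compound 2 also returned only a limit, so no step can be read between compound 2 and compound 3. The compounds shown leave open whether any group at this saturated ring carbon would return a numbered value.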